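The source may hold more compounds than are shown below. What is called first, only, known or untested is meant among the compounds shown, and "the series" means these compounds.

Working notes on the series. The core is shared; the compounds differ in the aryl group on the sulfonyl sulfur and in where the fluorine sits on the core. Compound 1 `Cc1ccc(S(=O)(=O)c2cnc3c(F)cccc3c2N2CCC(C)CC2)cc1F` in an assay on isolated protein for displacement of a labelled ligand from metabotropic glutamate receptor 5 (Homo sapiens), with a stated time of 60 min, tested at 1 uM (a higher number here means more inhibition at the concentration tested (going by the name of the read-out), a lower number less inhibition), gives 93%. Compound 2 `CC1CCN(c2c(S(=O)(=O)c3ccc(Cl)c(Cl)c3)cnc3ccc(F)cc23)CC1` in this assay gives 91%; the two numbers lie within the scatter of each other, so no order between compound 1 and compound 2 can be read from them. Both sit near the top of the scale at the tested concentration.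

Compound 3 `CC1CCN(c2c(S(=O)(=O)c3ccc(F)c(Cl)c3)cnc3c(F)cccc23)CC1` is not yet measured in this assay. It differs from compound 1 in one place: 3-chloro-4-fluorophenyl in place of 3-fluoro-4-methylphenyl on a sulfonyl sulfur. Among the compounds with values here, no measured step of this kind exists. Given that compound 2, with its own dihalogenated aryl group, gives 91%, the step from compound 1 to compound 3 is expected to be a number 3 percentage points lower from compound 1 to compound 3 (within the scatter), none beyond the scatter. Compound 3 is estimated at 90%, in the range 78% to 97%.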

Compound 3, a percentage reported as inhibition, at one concentration (the size of the read-out at that concentration, not a potency): 95%
Compound 3: middle estimate off by 5 percentage points, on the low side, and the stated range covers the measured number.
By their numbers in this assay, from the lowest: compounds 2, 1 and 3 (each within the scatter of the next).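

Within the data shown here, on the sulfonyl sulfur, 3-chloro-4-fluorophenyl in place of 3-fluoro-4-methylphenyl gives the only single-place step so far in this assay, a number 2 percentage points higher from compound 1 to compound 3 (within the scatter), so no difference between these two aryl groups can be read. Compound 3 carries no methyl on that aryl group and still sits near the top of the scale, so a methyl there is not required for a high read-out at the tested concentration. No measurement is at hand that bears on the reason for this result.

Open, as far as these compounds go, is whether a sulfonyl substituent such as an aryl group bearing a carboxylic acid or an amine, or a plain alkyl chain, would give a lower read-out. Compound 2 differs from compound 1 and compound 3 in more than one place, so the role of the fluorine's place on the core remains unresolved.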